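The source may report more compounds than this note shows. Statements on the series, on what has been measured and on what is new or still open speak of the compounds shown alone.

In a functional assay on MCF7 cells (Homo sapiens) for antiproliferative activity, read by sulforhodamine B assay, with a stated time of 48 h (a lower number here means a stronger inhibitor, a higher number a weaker inhibitor), compound 1 `Cc1ccc(S(=O)(=O)Nc2ccc(-c3ccnc(Nc4ccc(S(=O)(=O)Nc5nccc(C)n5)cc4)c3C#N)cc2)cc1` gives 18300 nM, and compound 2 `COc1ccccc1/C=C/C(=C(C#N)C#N)c1ccc(NS(=O)(=O)c2ccc(C)cc2)cc1` gives 26300 nM. Within the data shown here, these two numbers lie within the usual scatter of each other, so compound 1 stands level with the only other measured compound and neither can be ranked above the other.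

Compound 3 `Cc1ccc(S(=O)(=O)Nc2ccc(-c3ccnc(Nc4ccc(S(=O)(=O)Nc5cc(C)no5)cc4)c3C#N)cc2)cc1` keeps the core of compound 1 and alters one group: 3-methyl-1,2-oxazol-5-yl in place of 4-methylpyrimidin-2-yl on a sulfonamide nitrogen. A six-membered aromatic ring thus gives way to a five-membered aromatic ring. Among the measured compounds shown here, no measured pair shows this kind of swap, so the expectation rests on the modest size of the change alone, and no shift beyond the scatter is expected in this assay. The expected step is a 1.2-fold lower number from compound 1 to compound 3 (0.09 log units; within the scatter). For compound 3 the estimated value is 15000 nM, with an expected range of 6000 nM to 40000 nM.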

Compound 3, half-maximal inhibitory concentration: 20400 nM
For compound 3 the middle estimate is 1.4-fold (0.13 log units) below the measured one; the measured number falls inside the stated range.
By their numbers in this assay, from the lowest: compounds 1, 3 and 2 (each within the scatter of the next).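

In this assay the first change measured on this sulfonamide nitrogen, 3-methyl-1,2-oxazol-5-yl in place of 4-methylpyrimidin-2-yl, gives a step that stays within the usual scatter (a 1.1-fold higher number from compound 1 to compound 3 (0.05 log units; within the scatter)). For this one pair, then, going from a six-membered to a five-membered aromatic ring leaves the antiproliferative reading unchanged within that scatter, so the two compounds stand level. No measurement at hand bears on why the two rings read alike.

On these data alone, both groups compared here are methyl-bearing aromatic rings with two hetero atoms, so it remains open how a different kind of group on this nitrogen, such as a plain phenyl ring or an acetyl group, would read. As far as these compounds go, it also remains open whether any change at this position can move the number beyond the scatter.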